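A Bare Triazole Nitrogen in Place of Naphthylmethyl

This account rests on a few compounds, and the source may have more. Where it says the series, first, only, none or still open, it means among the compounds named here.

Measured in a functional assay on HCT-116 cells (Homo sapiens) for inhibition, read by MTT assay, with a stated time of 72 h; on this read-out lower numbers stand for stronger inhibition of growth and higher numbers for weaker inhibition of growth
compound 1 `O[C@H](COCCOC[C@@H](O)Cc1cn(Cc2ccc3ccccc3c2)nn1)Cc1ccc(-c2ccccc2)cc1` gives 8600 nM
compound 2 `CC1=C(CCCCCCCCCCn2cc(C[C@H](O)COCCOC[C@@H](O)Cc3ccc(-c4ccccc4)cc3)nn2)C(=O)c2ccccc2C1=O` gives 3000 nM
compound 3 `O[C@H](COCCOC[C@@H](O)Cc1cn(Cc2cccc(-c3ccccc3)c2)nn1)Cc1ccc(-c2ccccc2)cc1` gives 7200 nM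

Compound 1 stands at the high end of these numbers, level with compound 3 within the scatter, while compound 2 lies lower at 3000 nM. Compound 4 `O[C@H](COCCOC[C@@H](O)Cc1c[nH]nn1)Cc1ccc(-c2ccccc2)cc1` keeps the core of compound 1 but carries hydrogen in place of (naphthalen-2-yl)methyl on an aromatic nitrogen. For the measured compounds named here, one measured step touches this place: a 1.2-fold lower number from compound 1 to compound 3 (0.08 log units; within the scatter), which stays within the scatter. That step exchanges one large aromatic group for another and removes none, so it says little about losing the group altogether. Going by the values given here, no measured compound has a bare nitrogen there, and the size of the step remains uncertain. All three measured compounds carry a large group at that nitrogen, and compound 1 at 8600 nM is the closest reference, so a move towards a higher number, meaning weaker growth inhibition, is expected in this assay. The estimate amounts to a 2.3-fold higher number from compound 1 to compound 4 (0.37 log units; beyond the scatter). Compound 4 is estimated at 20000 nM, with an expected range from 8000 nM to 60000 nM.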

Compound 4, concentration for 50% growth inhibition: > 100000 nM
Compound 4: no number, only a limit; the forecaster's own chance of this, stated with the estimate: 30%; middle value at least 5.0-fold (0.69 log units) away from the limit.
By their numbers in this assay, from the lowest: compound 2; then compounds 3 and 1 (each within the scatter of the next). At a limit, above all of these: compound 4.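

In this assay compound 4 gives only a limit, > 100000 nM. Hydrogen in place of (naphthalen-2-yl)methyl on the aromatic nitrogen produces an at least 11-fold higher number from compound 1 to compound 4 (1.06 log units; beyond the scatter), whereas the exchange of one large aromatic group for another at the same place produced a 1.2-fold lower number from compound 1 to compound 3 (0.08 log units; within the scatter), so this position shows a clear response to losing the group altogether, which the earlier exchange could not reveal. The step has only a lower bound, and its true size cannot be read past the limit of the assay: the limit of > 100000 nM in this assay, at which 1 of the 4 values shown sits.

The compounds shown leave open whether a methyl group, a benzyl group or a hexyl chain on that nitrogen would fall nearer to compound 1 or to compound 4. They also leave open how an amine or a carboxylic acid at the end of such a chain would behave.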